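The source may hold more compounds than are shown below. What is called first, only, known or untested is meant among the compounds shown, and "the series" means these compounds.

Working notes on a nitro-substituted, trifluoromethyl-bearing series, three members of which have been run in an ADME assay on microsomes from liver (Homo sapiens) for metabolic stability, read by LC-MS, using NADPH, with a stated time of 30 min, tested at 1 uM; a higher number here means that more of the compound is left, a lower number that less of the compound is left. Compound 1 `O=c1nc(N2CCN(CC3CCCCC3)CC2)sc2c([N+](=O)[O-])cc(C(F)(F)F)cc12` gives 58.7% in this assay. Compound 2 `CN(Cc1ccccc1)c1cc(=O)c2cc(C(F)(F)F)cc([N+](=O)[O-])c2s1` gives 11.6% in this assay. Compound 3 `O=c1cc(N2CCN(CC3CCCCC3)CC2)sc2c([N+](=O)[O-])cc(C(F)(F)F)cc12` gives 66.7% in this assay. Compound 3 therefore holds the highest of the three numbers, but compound 1 lies within the usual scatter of it, so the two cannot be ordered; compound 2 sits far below both, well beyond the scatter. Among the compounds with values here, no pair among the three differs in a single place, so no single step can be drawn from what has been measured.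

Compound 4 `CC1CN(c2cc(=O)c3cc(C(F)(F)F)cc([N+](=O)[O-])c3s2)CCN1CC1CCCCC1` has not yet been run in this assay. It differs from compound 3 in this way: methyl in place of hydrogen on a saturated ring carbon. The change leaves the cyclohexylmethyl group and the shared core untouched and adds a single carbon with no donors or acceptors. Against the gap between compound 1 and compound 3, which is within the scatter, no movement beyond the scatter is expected here, and the direction is not predictable from the data at hand. Compound 4 is expected to give 62%, with a range of 45% to 78%. This expectation corresponds to a step of a number 4.7 percentage points lower from compound 3 to compound 4 (within the scatter), which is within the scatter.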

Compound 4, percent of the compound remaining: 62.7%
Compound 4: the middle estimate sits 0.7 percentage points below what was measured, within the range that was stated.
By their numbers in this assay, from the lowest: compound 2; then compounds 1, 4 and 3 (each within the scatter of the next).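

In this assay, within the data shown here, methyl in place of hydrogen on a saturated ring carbon, next to the ring nitrogen, gives a number 4 percentage points lower from compound 3 to compound 4 (within the scatter) and so no step that can be told from the scatter. Among these compounds, this is the first comparison that differs in one place only, and it shows that this ring carbon of the six-membered non-aromatic ring with 2 nitrogen carries a methyl with compound 3 and compound 4 left unordered, the cyclohexylmethyl group and the shared core being the same in both. Nothing in the data given bears on why the step is this size, so no cause can be stated for it.

From the compounds shown here alone, what a group other than methyl, such as ethyl, hydroxymethyl or a carboxylic acid, would give on this same carbon stays open, as does a methyl on the ring carbon two ring bonds from the ring nitrogen. Going by these compounds, whether the same methyl gives a step of like size on the core of compound 1 also stays open, since one step on one core cannot settle it.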